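The source may hold more compounds than are shown below. What is called first, only, known or untested is meant among the compounds shown, and "the series" means these compounds.

Of the compounds shown here, three built on one shared core have been measured in an assay on MDA-MB-231 cells for displacement of a labelled ligand from C-X-C chemokine receptor type 4 (Homo sapiens), read by fluorescence and microscopy, with stated times of 10 min and 30 min; a higher number here means that more compound is needed for the effect, a lower number that less compound is needed. Compound 1 `Cc1ccccc1C(=O)NCc1ccc(CNS(=O)(=O)c2ccc(F)cc2)cc1` gives 10 nM in this assay. Compound 2 `O=C(NCc1ccc(CNS(=O)(=O)c2ccc(F)cc2)cc1)c1cccnc1` differs from compound 1 by pyridin-3-yl in place of 2-methylphenyl on a carbonyl carbon, and in this assay compound 2 gives 100 nM, a step of a 10-fold higher number from compound 1 to compound 2 (1.00 log units; beyond the scatter). Compound 3 `Cc1ccccc1C(=O)NCc1ccc(CNS(=O)(=O)c2cccc(Cl)c2)cc1` differs from compound 1 by 3-chlorophenyl in place of 4-fluorophenyl on a sulfonyl sulfur, and in this assay compound 3 gives 100 nM, a step of a 10-fold higher number from compound 1 to compound 3 (1.00 log units; beyond the scatter). At the digits given, compound 2 and compound 3 sit level.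

Compound 4 `O=C(NCc1ccc(CNS(=O)(=O)c2cccc(Cl)c2)cc1)c1cccnc1` has not yet been measured. It differs from compound 3 by pyridin-3-yl in place of 2-methylphenyl on a carbonyl carbon, at a carbonyl carbon whose other neighbour is an amide-type nitrogen, which is the same change that turns compound 1 into compound 2; the two cores on which it is made differ by 3-chlorophenyl in place of 4-fluorophenyl on a sulfonyl sulfur. Within the data shown here, the expectation rests on the single earlier example of this change, a 10-fold higher number from compound 1 to compound 2 (1.00 log units; beyond the scatter), carried over unchanged onto compound 3. Carrying that size onto compound 3 gives an expected 10-fold higher number from compound 3 to compound 4 (1.00 log units; beyond the scatter). In this assay compound 4 is therefore estimated at 1000 nM, with a plausible range from 250 nM to 4000 nM.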

Compound 4, effective concentration (reported as EC, without a stated level of effect): 100 nM
Beside the measured number, compound 4's estimate is 10-fold (1.00 log units) above it; the measured number lies below the stated range.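

In this assay, the swap of 2-methylphenyl for pyridin-3-yl on the carbonyl carbon does not carry over from one core to the other, since it now gives no change at the digits printed from compound 3 to compound 4 (within the scatter): the same change on two cores in this assay, a 10-fold higher number (1.00 log units; beyond the scatter) from compound 1 to compound 2 and no change at the digits printed (within the scatter) from compound 3 to compound 4, 10-fold (1.00 log units) apart, beyond the scatter of two such steps
Read the other way, the swap of 4-fluorophenyl for 3-chlorophenyl on the sulfonyl sulfur also fails to carry over, giving no change at the digits printed from compound 2 to compound 4 (within the scatter): the same change on two cores in this assay, a 10-fold higher number (1.00 log units; beyond the scatter) from compound 1 to compound 3 and no change at the digits printed (within the scatter) from compound 2 to compound 4, 10-fold (1.00 log units) apart, beyond the scatter of two such steps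
So, among these four compounds, the size of a step at one of these two places depends on the group at the other, and a step measured on one core cannot simply be added onto another; what the data do not show is why this happens, or whether it holds beyond this single set of four.

Going by these compounds, it remains open how other groups on the carbonyl carbon, such as plain phenyl or pyridin-4-yl, would behave on these two cores. The same question stands for other groups on the sulfonyl sulfur, such as 4-chlorophenyl or a simple methyl.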